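A Benzyloxy Compound Weighed Against Its Nitro Neighbour

A few compounds are considered here, and "the series" means these few. Any claim that something is new, unique, unknown or untested is made for them only; others in the source may bear on it.

Measured so far:
compound 1, `CSc1ccc(C2=NN(C(=S)Nc3ccccc3)C(c3ccc4c(c3)OCCO4)C2)cc1`, > 200000 nM (a limit of the assay)
compound 2, `O=[N+]([O-])c1ccc(C2=NN(C(=S)Nc3ccccc3)C(c3ccc4c(c3)OCCO4)C2)cc1`, 153000 nM

Among the measured compounds shown here, in a functional assay on HT-29 cells (Homo sapiens) for antiproliferative activity, read by MTT assay, with a stated time of 48 h (on this read-out lower numbers stand for stronger inhibition of growth and higher numbers for weaker inhibition of growth), compound 2 gives 153000 nM, the only actual number recorded. Compound 1 stops at a limit of this assay, > 200000 nM. For the measured compounds named here, the single measured step, an at least 1.3-fold lower number from compound 1 to compound 2 (0.11 log units; that floor lies within the scatter), rests on that limit and so says little. Compound 3 is `S=C(Nc1ccccc1)N1N=C(c2ccc(OCc3ccccc3)cc2)CC1c1ccc2c(c1)OCCO2`; it differs from compound 2 by benzyloxy in place of nitro on an aromatic carbon. Going by the values given here, no measured step involves a benzyloxy group, so no shift beyond the scatter is expected. Compound 3 is estimated at 130000 nM, within 40000 nM to 350000 nM. The expected step is a 1.2-fold lower number from compound 2 to compound 3 (0.07 log units; within the scatter).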

Compound 3, concentration for 50% growth inhibition: 860 nM
Compound 3: middle estimate off by 150-fold (2.18 log units), on the high side; the measured number lies below the stated range.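

Among the compounds shown here, at this position, para to a large group, the choice of group can matter far more than the first pair of compounds could show. Benzyloxy in place of nitro gives a large change in this assay (a 180-fold lower number from compound 2 to compound 3 (2.25 log units; beyond the scatter)). Benzyloxy in place of methylsulfanyl also gives a large change (an at least 230-fold lower number from compound 1 to compound 3 (2.36 log units; beyond the scatter)), but that figure is only a floor, as it rests on a limit of the assay: the limit of > 200000 nM in this assay, at which 1 of the 3 values shown sits.

The compounds shown leave open which part of benzyloxy matters, its oxygen or its aromatic ring. They also leave open how a methoxy group, a longer phenylpropoxy chain or an amine would compare here.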